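Adding a methoxy to a longer-chain sigma-2 ligand

The source may hold more compounds than are shown below. What is called first, only, known or untested is meant among the compounds shown, and "the series" means these compounds.

Compound 1 `COc1cc2c(cc1OC)CN(CCCCC(=O)c1c(C)c(OC)c(OC)c(OC)c1OC)CC2`: 3 nM
Compound 2 `COc1cc2c(c(OC)c1OC)CCN(CCCCC(=O)c1c(C)c(OC)c(OC)c(OC)c1OC)C2`: 34.2 nM
Compound 3 `COc1cc2c(cc1OC)CN(CCCCCC(=O)c1c(C)c(OC)c(OC)c(OC)c1OC)CC2`: 0.38 nM

Of the compounds shown here, three have been measured in an assay on membranes from liver for displacement of a labelled ligand from Sigma intracellular receptor 2 (Rattus norvegicus), read by scintillation counting, with a stated time of 120 min; a higher number here means a weaker inhibitor, a lower number a stronger inhibitor. Compound 1 gives 3 nM in this assay. Compound 2 differs from compound 1 by one change, (methoxy in place of hydrogen on an aromatic carbon), and this gave an 11-fold higher number from compound 1 to compound 2 (1.06 log units; beyond the scatter). Compound 3, in the same assay, gives 0.38 nM, the lowest number of the three; the difference between the core of compound 3 and that of compound 1 is not broken down here, so only the two values themselves can be compared.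

Compound 4 `COc1cc2c(c(OC)c1OC)CN(CCCCCC(=O)c1c(C)c(OC)c(OC)c(OC)c1OC)CC2` has not yet been measured in this assay. It stands to compound 3 as compound 2 stands to compound 1: the change is methoxy in place of hydrogen on an aromatic carbon, and the place described for it is the same, word for word, as in the earlier pair, so this is the same change made on a second core.

Since the same change in compound 1 to compound 2 gave a step well beyond the usual scatter, the step from compound 3 to compound 4 is expected to be of similar size and direction, estimated at a 9.2-fold higher number from compound 3 to compound 4 (0.96 log units; beyond the scatter), because of an 11-fold higher number from compound 1 to compound 2 (1.06 log units; beyond the scatter). Compound 4 is therefore estimated to give 3.5 nM in this assay, with an expected range from 1 nM to 12 nM. This rests on a single earlier example of the change, so the estimate carries real uncertainty.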

Compound 4, inhibition constant: 12.6 nM
Compound 4: the middle estimate sits 3.6-fold (0.56 log units) below what was measured; the whole stated range lies below it.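

On the second core, the added methoxy again gave a weaker inhibitor in this assay, with a 33-fold higher number from compound 3 to compound 4 (1.52 log units; beyond the scatter). The direction of the change therefore held on both cores, but its size did not, and the gap between the two steps is larger than repeated measurements would be expected to produce: the same change on two cores in this assay, an 11-fold higher number (1.06 log units; beyond the scatter) from compound 1 to compound 2 and a 33-fold higher number (1.52 log units; beyond the scatter) from compound 3 to compound 4, 2.9-fold (0.46 log units) apart, beyond the scatter of two such steps. This shows that, in these two pairs, the methoxy step depends on the core that carries it, but two pairs cannot show which feature of the cores sets its size, or how large the step would be on a third core.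

The compounds shown leave open what a group other than methoxy, such as a hydroxy group or a chlorine atom, would do on the same aromatic carbon, and so whether the loss in binding is particular to methoxy. They also leave open whether the same direction would hold with a longer chain, which would show whether the larger step seen on the second core continues to grow or was specific to that core.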